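The source may report more compounds than this note shows. Statements on the series, on what has been measured and on what is new or still open speak of the compounds shown alone.

Measured compounds
- compound 1: `CCc1nc2ccccc2n1CCCCOc1ccc(Cl)cc1Cl`; an ADME assay on Vero cells (Chlorocebus sabaeus) for cytotoxicity, read by luminescence, with a stated time of 2 days; on this read-out lower numbers stand for higher toxicity in this test and higher numbers for lower toxicity in this test: 23 uM
- compound 2: `CCc1nc2cc(OC)ccc2n1CCCCOc1ccccc1`; this assay: "not determined" (no result reported)

Within the data shown here, compound 1 is the only compound of the series with a number in this assay; compound 2 carries no result there, so nothing can be set beside compound 1, and no step between measured compounds exists. Compound 3 is `CCc1nc2ccccc2n1CCCCOC`. It differs from compound 1 in one place: methyl in place of 2,4-dichlorophenyl on an oxygen on a saturated carbon. The change strips the larger substituent from the chain end and leaves the shared core with a short ether end. Among the measured compounds shown here, with no measured step to lean on, the size of the move can only be judged from the change itself. In this assay the expected direction is toward a higher number, that is, lower toxicity, by more than the usual scatter, though how much the core alone contributes is not known from these two entries. Compound 3 is therefore expected to give 65 uM, within 25 uM to 160 uM. The expected step amounts to a 2.8-fold higher number from compound 1 to compound 3 (0.45 log units; beyond the scatter). A result reported only as a limit would not be surprising.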

Compound 3, half-maximal toxic concentration: > 50 uM
Compound 3 ended at the assay's limit; the forecaster's own chance of this, stated with the estimate: 30%; the middle value lies beyond the limit too.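

Among these compounds, this is the first comparison at this position. Methyl in place of 2,4-dichlorophenyl on an oxygen on a saturated carbon gives an at least 2.1-fold higher number from compound 1 to compound 3 (0.33 log units; beyond the scatter) in this assay, so the group on this oxygen has a clear bearing on the read-out, and the shared core with its chain does not by itself reach the level of compound 1. For compound 3, the entry of > 50 uM is a limit of the assay and not a number. The step therefore fixes only a minimum size for the change, and its full size remains unknown: the limit of > 50 uM in this assay, at which 1 of the 3 values shown sits.

From the compounds shown here alone, what remains open is whether the step follows the aromatic ring, its two chlorine atoms or simply the size of the group, and a 4-chlorophenyl or a cyclohexyl on the same oxygen would separate these readings. Also open, going by these compounds, is whether the same step holds on a core carrying a methoxy group, as in compound 2, which has no result here, and how an amine at the chain end would read in this assay.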